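Trimming a methoxy to a hydroxy

The source may report more compounds than this note shows. Statements on the series, on what has been measured and on what is new or still open speak of the compounds shown alone.

In a functional assay on DU-145 cells (Homo sapiens) for cytotoxicity, read by trypan blue exclusion, with a stated time of 96 h (on this read-out lower numbers stand for stronger inhibition and higher numbers for weaker inhibition), compound 1 (`COc1ccc(CS(=O)(=O)/C=C/c2c(OC)cccc2OC)cc1[N+](=O)[O-]`) gives 20000 nM, and compound 2 (`COc1cc(OC)c(/C=C/S(=O)(=O)Cc2ccc(OC)c([N+](=O)[O-])c2)c(OC)c1`) gives 2500 nM, the lower of the two numbers. Compound 3 (`COc1ccc(CS(=O)(=O)/C=C/c2c(OC)cc(O)cc2OC)cc1[N+](=O)[O-]`) has not yet been measured. It differs from compound 2 by one small edit, methoxy to hydroxy: hydrogen in place of methyl on an oxygen on an aromatic ring. Within the data shown here, only one measured step bears on this, an 8.0-fold lower number from compound 1 to compound 2 (0.90 log units; beyond the scatter), in which a methoxy came in place of hydrogen on an aromatic carbon. The edit alters that same methoxy. A hydroxy, however, is neither the hydrogen of compound 1 nor the methoxy of compound 2, so this step suggests a direction but only loosely a size. A higher number is expected in this assay, probably without going all the way back to compound 1. The expected change is a 2.4-fold higher number from compound 2 to compound 3 (0.38 log units; beyond the scatter). For compound 3, the estimated value is 6000 nM, with an expected range of 1500 nM to 20000 nM.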

Compound 3, half-maximal inhibitory concentration: 5000 nM
For compound 3 the middle estimate is 1.2-fold (0.08 log units) above the measured one, and the stated range covers the measured number.
By their numbers in this assay, from the lowest: compounds 2 and 3 (each within the scatter of the next); then compound 1.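

In this assay the methyl on this oxygen can go without a change that stands clear of the usual scatter: a 2.0-fold higher number from compound 2 to compound 3 (0.30 log units; within the scatter) is all that separates the two, so methoxy and hydroxy cannot be told apart here. Hydroxy still stands clear of plain hydrogen on the aromatic carbon, as a 4.0-fold lower number from compound 1 to compound 3 (0.60 log units; beyond the scatter) shows, and this step joins an 8.0-fold lower number from compound 1 to compound 2 (0.90 log units; beyond the scatter) as a second one beyond the scatter. The gain seen with the methoxy therefore does not rest on keeping the methyl, and no supporting data are available to explain this result.

As far as these compounds go, whether the oxygen itself is needed remains open, since an amine or a fluorine in its place would test that. From the compounds shown here alone, a longer chain on the oxygen, such as ethoxy, also remains unexplored, so how much size this place tolerates is unknown.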